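Rat Liver Microsome Half-Life Across Three Ester Side Chains

The source may hold more compounds than are shown below. What is called first, only, known or untested is meant among the compounds shown, and "the series" means these compounds.

Measured compounds:
compound 1 `CCOc1cc(NC(=O)C2(NC(=O)c3ccc4c(C5CCCC5)c(-c5ncc(Cl)cn5)n(C)c4c3)CCC2)ccc1/C=C/C(=O)OCCOCCOC`: 1.07 h
compound 2 `CCOc1cc(NC(=O)C2(NC(=O)c3ccc4c(C5CCCC5)c(-c5ncc(Cl)cn5)n(C)c4c3)CCC2)ccc1/C=C/C(=O)OCC(=O)N(C)C(C)C`: 0.267 h

In an ADME assay (liver) for pharmacokinetics, with Liver microsome (Rattus norvegicus) as the target, using microsomes (a lower number here means that the compound disappears faster, a higher number that the compound lasts longer), compound 2 gives 0.267 h, the lower of the two numbers measured. Compound 1 gives 1.07 h. Among the measured compounds shown here, the only measured step, a 4.0-fold lower number from compound 1 to compound 2 (0.60 log units; beyond the scatter), lies beyond the scatter and exchanged the whole (2-methoxyethoxy)methyl chain for the isopropyl(methyl)carbamoyl group.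

Compound 3 `CCOc1cc(NC(=O)C2(NC(=O)c3ccc4c(C5CCCC5)c(-c5ncc(Cl)cn5)n(C)c4c3)CCC2)ccc1/C=C/C(=O)OCC(=O)N1CCOCC1` keeps that carbamoyl and differs from compound 2 only in the amine part: morpholin-4-yl in place of isopropyl(methyl)amino on a carbonyl carbon. For the measured compounds named here, no measured step covers this kind of change, so the one step known gives no direct guidance, and the expectation is a step that stays within the scatter, with a slight lean toward a shorter half-life. Compound 3 is therefore estimated at 0.25 h, with a range from 0.1 h to 0.65 h. The expected step from compound 2 to compound 3 is a 1.1-fold lower number from compound 2 to compound 3 (0.03 log units; within the scatter).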

Compound 3, half-life: 0.733 h
Estimate against measurement, compound 3: 2.9-fold (0.47 log units) below; measured number outside the range, above it.
By their numbers in this assay, from the lowest: compound 2; then compounds 3 and 1 (each within the scatter of the next).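

In this assay, the amine part of this carbamoyl proves to matter: a 2.7-fold higher number from compound 2 to compound 3 (0.44 log units; beyond the scatter), so a carbamoyl on this saturated chain carbon does not by itself bring the short half-life of compound 2. Measured against the (2-methoxyethoxy)methyl chain, the (morpholin-4-yl)carbonyl group gives a 1.5-fold lower number from compound 1 to compound 3 (0.16 log units; within the scatter), leaving compound 1 and compound 3 indistinguishable in this assay. Nothing available here explains why exchanging isopropyl(methyl)amino for morpholin-4-yl changes the half-life.

The compounds shown do not separate the contribution of the ring from that of its oxygen, a question that a piperidin-1-yl group on the same carbonyl carbon would address. They also leave open how a smaller dimethylamino group would behave at this place.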